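Aromatic amine swap on a furazan-fused core

A few compounds are considered here, and "the series" means these few. Any claim that something is new, unique, unknown or untested is made for them only; others in the source may bear on it.

Compound 1, `Fc1ccccc1Nc1nc2nonc2nc1NC1CCCCC1`: 13400 nM
Compound 2, `Fc1ccc(Nc2nc3nonc3nc2Nc2ccccc2F)c(F)c1`: 300 nM
Compound 3, `COc1ccc(Nc2nc3nonc3nc2Nc2ccccc2F)cc1`: 1600 nM

Three compounds share a core and differ only in the group on one nitrogen. In an assay on mitochondria from L6 cells (Rattus norvegicus) for activation, with a stated time of 90 min (on this read-out lower numbers stand for an effect already at smaller amounts and higher numbers for an effect only at larger amounts of compound), compound 1 gives 13400 nM, while compound 2 gives 300 nM and compound 3 gives 1600 nM. Compound 3 thus stands second highest of the three numbers, with a 5.3-fold higher number from compound 2 to compound 3 (0.73 log units; beyond the scatter) and an 8.4-fold lower number from compound 1 to compound 3 (0.92 log units; beyond the scatter) placing it between the other two, both gaps beyond the scatter.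

Compound 4, `Oc1ccc(F)c(Nc2nc3nonc3nc2Nc2ccccc2F)c1`, has not yet been measured in this assay. Its change from compound 3 is 2-fluoro-5-hydroxyphenyl in place of 4-methoxyphenyl on a nitrogen on an aromatic ring. Among the measured compounds shown here, the only measured step that bears on it is a 5.3-fold higher number from compound 2 to compound 3 (0.73 log units; beyond the scatter), which shows that a fluorine-bearing aryl group gave a lower number than the 4-methoxyphenyl. For the measured compounds named here, compound 4 keeps one fluorine and adds a hydroxyl, for which no step exists, so the expected effect is a modest lowering, weaker than that step. Compound 4 is therefore estimated at 600 nM, with a range of 200 nM to 1800 nM, meaning an expected step of a 2.7-fold lower number from compound 3 to compound 4 (0.43 log units; beyond the scatter).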

Compound 4, half-maximal effective concentration: 30000 nM
For compound 4 the middle estimate is 50-fold (1.70 log units) below the measured one; measured number outside the range, above it.
By their numbers in this assay, from the lowest: compound 2; then compound 3; then compound 1; then compound 4.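

Keeping a fluorine on the aryl group does not hold the number low at this position: in this assay the change to 2-fluoro-5-hydroxyphenyl brings a 19-fold higher number from compound 3 to compound 4 (1.27 log units; beyond the scatter) and, set against 2,4-difluorophenyl, a 100-fold higher number from compound 2 to compound 4 (2.00 log units; beyond the scatter) on the same nitrogen. An aromatic ring here also does not by itself give a lower number than cyclohexyl, as this group brings a 2.2-fold higher number from compound 1 to compound 4 (0.35 log units; beyond the scatter) and so reverses the direction seen with the other two aryl groups. No measurement shown here accounts for this rise.

The fluorine and the hydroxyl enter together on one ring, so the compounds shown do not separate what each contributes. From the compounds shown here alone, whether an amine or a carboxylic acid in place of the hydroxyl would bring the number back down also stays open.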